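Chain extension on the amide of compound 3

The source may report more compounds than this note shows. Statements on the series, on what has been measured and on what is new or still open speak of the compounds shown alone.

The three measured compounds, compound 1 `COc1cc(N(C)CCN(C)C)c(NC(=O)/C=C\C(C)C)cc1Nc1nccc(-c2cn(C)c3ccccc23)n1`, compound 2 `C=C(Cl)C(=O)Nc1cc(Nc2ncc(C#N)c(-c3cn(C)c4ccccc34)n2)c(OC)cc1N(C)CCN(C)C` and compound 3 `C=CC(=O)Nc1cc(Nc2nc(C)cc(-c3cn(C)c4ccccc34)n2)c(OC)cc1N(C)CCN(C)C`, share one core and differ at the amide and on the core itself. In a functional assay on NCI-H1975 cells (Homo sapiens) for antiproliferative activity, read by MTT assay, with a stated time of 72 h (on this read-out higher numbers stand for weaker inhibition and lower numbers for stronger inhibition), compound 1 gives 1820 nM, compound 2 gives 1620 nM and compound 3 gives 4810 nM, the highest of the three numbers, with both gaps to it beyond the scatter. Within the data shown here, no pair among them differs in one place only. Compound 4 `CCC/C=C\C(=O)Nc1cc(Nc2nc(C)cc(-c3cn(C)c4ccccc34)n2)c(OC)cc1N(C)CCN(C)C` differs from compound 3 by pent-1-en-1-yl in place of vinyl on a carbonyl carbon. Among the measured compounds shown here, no measured pair shows this change, so a small upward step at most, possibly none beyond the scatter, is expected: a 1.4-fold higher number from compound 3 to compound 4 (0.13 log units; within the scatter) is the estimated step. Compound 4 is expected near 6500 nM, within 2500 nM to 16000 nM.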

Compound 4, half-maximal inhibitory concentration: 254 nM
For compound 4 the middle estimate is 26-fold (1.41 log units) above the measured one, outside the stated range (below it).
By their numbers in this assay, from the lowest: compound 4; then compounds 2 and 1 (each within the scatter of the next); then compound 3.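

In this assay, the step to the longer chain is large: a 19-fold lower number from compound 3 to compound 4 (1.28 log units; beyond the scatter). On this core, the substituent on the carbonyl carbon therefore strongly affects the read-out, and pent-1-en-1-yl in place of vinyl, with one double bond outside aromatic rings on each side, is far from detrimental. Nothing available explains the gain. On these data alone, whether it depends on chain length or on the double bond remains open. A saturated pentyl group, a longer alkenyl chain or an amine in place of pent-1-en-1-yl would help separate these possibilities.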